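Replacing 2-chlorophenyl with 4-nitrophenyl in a cytotoxic series

This account rests on a few compounds, and the source may have more. Where it says the series, first, only, none or still open, it means among the compounds named here.

Measured in a functional assay on MCF7 cells (Homo sapiens) for cytotoxicity, read by MTT assay, with a stated time of 96 h; a lower number here means a stronger inhibitor, a higher number a weaker inhibitor:
- compound 1 `COc1cc(C(=O)c2cn(-c3cccc(N)c3)cc2-c2ccc([N+](=O)[O-])cc2)cc(OC)c1OC`: 110 nM
- compound 2 `COc1cc(C(=O)c2cn(-c3ccc(F)cc3)cc2-c2ccccc2F)cc(OC)c1OC`: 39 nM
- compound 3 `COc1cc(C(=O)c2cn(-c3ccc(F)cc3)cc2-c2ccccc2Cl)cc(OC)c1OC`: 83 nM

Compound 3 gives 83 nM, which lies within the usual scatter of the value for compound 1. Within the data shown here, the one measured step that reaches it is modest but beyond the scatter: a 2.1-fold higher number from compound 2 to compound 3 (0.33 log units; beyond the scatter).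

The next structure is compound 4 `COc1cc(C(=O)c2cn(-c3ccc(F)cc3)cc2-c2ccc([N+](=O)[O-])cc2)cc(OC)c1OC`, which carries 4-nitrophenyl in place of 2-chlorophenyl on an aromatic carbon. Among the measured compounds shown here, no measured step covers this exchange directly. For the measured compounds named here, the nearest guide is a 2.1-fold higher number from compound 2 to compound 3 (0.33 log units; beyond the scatter), but that step changes only one halogen on the group that now leaves, so it offers just a rough sense of scale. Compound 1 also carries the 4-nitrophenyl group, though it differs from compound 4 elsewhere, and compound 1 gives 110 nM. On this evidence, no step beyond the scatter is expected in this assay, and the data set no firm direction. The estimated change is small: a 1.1-fold higher number from compound 3 to compound 4 (0.04 log units; within the scatter). The expected value for compound 4 is 90 nM, with an estimated range from 30 nM to 270 nM.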

Compound 4, half-maximal inhibitory concentration: 240 nM
Estimate against measurement, compound 4: 2.7-fold (0.43 log units) below; measured number inside the range.
By their numbers in this assay, from the lowest: compound 2; then compounds 3 and 1 (each within the scatter of the next); then compound 4.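

In this assay the 4-nitrophenyl group on this aromatic carbon, two ring bonds from the ring nitrogen, replaces a whole substituted phenyl group rather than one halogen, and it gives a 2.9-fold higher number from compound 3 to compound 4 (0.46 log units; beyond the scatter) and also a 6.2-fold higher number from compound 2 to compound 4 (0.79 log units; beyond the scatter) against the two halogen-bearing phenyl groups. Compound 4 therefore has the highest number of the four, beyond the scatter of each of the others, which shows that this place responds to more than the exchange of fluoro for chloro. The result also shows that the group on the ring nitrogen counts when 4-nitrophenyl is held fixed: 4-fluorophenyl in place of 3-aminophenyl gives a 2.2-fold higher number from compound 1 to compound 4 (0.34 log units; beyond the scatter) and leaves compound 1 with the lower number.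

The compounds shown leave open whether the nitro group or its place on the phenyl ring carries the step, a question that a 2-nitrophenyl or a 4-chlorophenyl group at this carbon would address. Nothing measured here bears on the cause of these steps.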